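Swapping an Alkynyl Arm for a Chlorophenyl Ring

The source may report more compounds than this note shows. Statements on the series, on what has been measured and on what is new or still open speak of the compounds shown alone.

Within the data shown here, compound 2 `Nc1ncnn2c([C@@H]3O[C@H](CO)[C@@H](O)[C@H]3O)cc(C#Cc3cccs3)c12` gives 26600 nM in a functional assay on NCI-H460 cells (Homo sapiens) for antiproliferative activity, with a stated time of 72 h (on this read-out higher numbers stand for weaker inhibition and lower numbers for stronger inhibition), the higher of the two numbers measured so far. Among the measured compounds shown here, its only measured neighbor is compound 1 `CCCCC#Cc1cc([C@@H]2O[C@H](CO)[C@@H](O)[C@H]2O)n2ncnc(N)c12`, which gives 1700 nM in this assay. For the measured compounds named here, the single known step, a 16-fold higher number from compound 1 to compound 2 (1.19 log units; beyond the scatter), exchanged the group attached to the triple bond. Compound 3 `Nc1ncnn2c([C@@H]3O[C@H](CO)[C@@H](O)[C@H]3O)cc(-c3ccccc3Cl)c12` goes further and removes the triple bond altogether: 2-chlorophenyl in place of 2-(thiophen-2-yl)ethynyl on an aromatic carbon. Going by the values given here, no measured step covers an aromatic ring set directly on the core, so neither direction is supported by data. Compound 3 is therefore expected near 5000 nM, within 1500 nM to 20000 nM, an estimated step of a 5.3-fold lower number from compound 2 to compound 3 (0.73 log units; beyond the scatter).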

Compound 3, half-maximal inhibitory concentration: > 100000 nM
Compound 3: no number, only a limit (the forecaster's own chance of this, stated with the estimate: 10%); middle value at least 20-fold (1.30 log units) from the limit.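

The number for compound 3 is a limit and not a measured value: the limit of > 100000 nM in this assay, at which 1 of the 3 values shown sits. Setting 2-chlorophenyl directly on this aromatic carbon, with no triple bond, gives an at least 3.7-fold higher number from compound 2 to compound 3 (0.57 log units; beyond the scatter), and against the hex-1-yn-1-yl arm it gives an at least 58-fold higher number from compound 1 to compound 3 (1.76 log units; beyond the scatter). Among these three compounds, then, only compound 1 and compound 2, which both carry a triple bond here, give a number in this assay.

Still open, going by these compounds, is whether the weaker inhibition follows the lost triple bond or the chlorine-bearing ring. An unsubstituted phenyl ring on the core, or a phenyl ring carried on a triple bond, would help separate the two.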